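Fluoro for Trifluoromethyl on the Pyridine Core of Compound 1

The source may report more compounds than this note shows. Statements on the series, on what has been measured and on what is new or still open speak of the compounds shown alone.

This account follows a single change made to compound 1 `C[C@@H]1CN(Cc2ccccc2)c2nc(C(F)(F)F)ccc2[C@H](C)N1C(=O)NCc1ccccc1`. In an assay on HEK293 cells for inhibition of Voltage-dependent T-type calcium channel subunit alpha-1I (Homo sapiens), read by FLIPR and calcium flux, with a stated time of 3 min (on this read-out higher numbers stand for weaker inhibition and lower numbers for stronger inhibition), compound 1 gives 281 nM, the highest of the two numbers that were read out. Compound 3 `C[C@@H]1CN(Cc2ccccc2)c2cncc(F)c2[C@H](C)N1C(=O)NCc1ccccc1`, which carries a fluoro on a different core, gives 9 nM, and the gap between compound 1 and compound 3 lies beyond the scatter. Compound 2 `C[C@@H]1CN(Cc2ccccc2)c2ccncc2[C@H](C)N1C(=O)NCc1ccccc1` reaches only a limit of this assay, > 8740 nM, and that is all that is known of it (the limit of > 8740 nM in this assay, at which 1 of the 3 values shown sits).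

The unmeasured compound 4 `C[C@@H]1CN(Cc2ccccc2)c2nc(F)ccc2[C@H](C)N1C(=O)NCc1ccccc1` differs from compound 1 in one place: fluoro in place of trifluoromethyl on an aromatic carbon. Within the data shown here, no pair with this same change has been measured, so the size of the step cannot be taken from a measured neighbour. Smaller substituents on the pyridine ring of this core have not been tested directly; compound 3 carries its fluoro on another ring system, so it serves only as a loose pointer. Compound 4 is expected to lie near compound 1, with a step of a 1.4-fold higher number from compound 1 to compound 4 (0.15 log units; within the scatter) that is estimated to stay within or only modestly beyond the scatter. For compound 4 the expected value is 400 nM, with a range from 120 nM to 1500 nM.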

Compound 4, half-maximal inhibitory concentration: 4 nM
For compound 4 the middle estimate is 100-fold (2.00 log units) above the measured one, outside the stated range (below it).
By their numbers in this assay, from the lowest: compound 4; then compound 3; then compound 1. At a limit, above all of these: compound 2.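

In this assay, putting fluoro in place of trifluoromethyl on the aromatic carbon next to the ring nitrogen gives a 70-fold lower number from compound 1 to compound 4 (1.85 log units; beyond the scatter). Among these compounds, this is the first single-place comparison at this position, and it shows that the read-out responds strongly to the group held there and that trifluoromethyl is not required for a low number on this core. Nothing shown measures a property that could account for the size of this step.

As far as these compounds go, with only these two groups compared at this position, it remains open how chloro, methoxy, nitrile or an amine placed there would read out in this assay. From the compounds shown here alone, it also remains open whether the same exchange would give a step of similar size on another core.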